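Shifting Fluorines on a Carbamate: Forecast for Compound 4

This account rests on a few compounds, and the source may have more. Where it says the series, first, only, none or still open, it means among the compounds named here.

Compound 1 `CC(C)=CCC/C(C)=C/CC1Cc2c(OCc3ccccc3)cc(=O)n(CCCO)c2CC1(C)C`: 1.5%
Compound 2 `CC(C)=CCC/C(C)=C/CC1Cc2c(OCC=C(C)C)cc(=O)n(CCCO)c2CC1(C)C`: 15.9%
Compound 3 `CC(C)=CCC/C(C)=C/CC1Cc2c(OC(=O)Nc3ccc(F)cc3F)cc(=O)n(CCCO)c2CC1(C)C`: 15.6%

Three compounds share one core and differ only in the group attached to the oxygen on the aromatic ring. In a functional assay on PANC-1 cells (Homo sapiens) for inhibition, read by MTT assay, with a stated time of 24 h, tested at 10 uM (a higher number here means more inhibition at the concentration tested (going by the name of the read-out), a lower number less inhibition), compound 3 stands second highest of the three numbers. Its nearest neighbour is compound 2, and the step of a number 0.3 percentage points lower from compound 2 to compound 3 (within the scatter) lies within the scatter, so the two cannot be told apart. Compound 1 sits furthest away, the step of a number 14.1 percentage points higher from compound 1 to compound 3 (beyond the scatter) being beyond the scatter.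

Compound 4 `CC(C)=CCC/C(C)=C/CC1Cc2c(OC(=O)Nc3ccc(F)c(F)c3)cc(=O)n(CCCO)c2CC1(C)C` is built from the same atoms as compound 3, joined differently: 3,4-difluorophenyl in place of 2,4-difluorophenyl on an amide-type nitrogen. Among the measured compounds shown here, no measured step changes only the placement of fluorine on that ring. The steps that touch this part of the molecule, a number 14.1 percentage points higher from compound 1 to compound 3 (beyond the scatter) and a number 0.3 percentage points lower from compound 2 to compound 3 (within the scatter), swap the whole group rather than move a fluorine, so they do not bear directly on the change. With nothing to point either way, a step beyond the scatter is not expected.

Compound 4 is therefore estimated at 15%, with an expected range from 3% to 30%. The expected step is a number 0.6 percentage points lower from compound 3 to compound 4 (within the scatter), which is estimated to stay within the scatter.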

Compound 4, a percentage reported as inhibition, at one concentration (the size of the read-out at that concentration, not a potency): 4.8%
Beside the measured number, compound 4's estimate is 10.2 percentage points above it; low and high end bracket the measured number.
By their numbers in this assay, from the lowest: compounds 1 and 4 (each within the scatter of the next); then compounds 3 and 2 (each within the scatter of the next).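

Moving a single fluorine, with the atoms otherwise unchanged, matters at this position: 3,4-difluorophenyl in place of 2,4-difluorophenyl on the amide-type nitrogen gives a number 10.8 percentage points lower from compound 3 to compound 4 (beyond the scatter) in this assay, so the carbamate link alone does not set the level of inhibition. The placement also changes how the carbamate compares with the other groups on the oxygen: a number 11.1 percentage points lower from compound 2 to compound 4 (beyond the scatter) opens a gap to the 3-methylbut-2-en-1-yl ether, while a number 3.3 percentage points higher from compound 1 to compound 4 (within the scatter) leaves compound 4 indistinguishable from the benzyl ether, the reverse of how compound 3 stands against these two. Nothing available explains why the fluorine placement has this effect.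

As far as these compounds go, whether a plain phenyl or a dichlorophenyl on the same nitrogen would read like compound 3 or like compound 4 remains open. So does whether the difference between these two compounds would hold at other concentrations.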